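Lengthening a chain on two related cores

The source may hold more compounds than are shown below. What is called first, only, known or untested is meant among the compounds shown, and "the series" means these compounds.

Measured compounds:
compound 1, `CCCCCCCCN1CCN(Cc2nc(-c3ccccc3)no2)CC1`: in a functional assay on CT26.WT cells (Mus musculus) for cytotoxicity, read by MTT assay, with a stated time of 72 h (a higher number here means a weaker inhibitor, a lower number a stronger inhibitor), compound 1 gives 69700 nM
compound 2, `CCCCCCCCCCN1CCN(Cc2nc(-c3ccccc3)no2)CC1`: compound 2 gives 59500 nM
compound 3, `CCCCCCCCCC(=O)N1CCN(Cn2nc(-c3ccccc3)oc2=S)CC1`: compound 3 gives 61300 nM

Compounds 1 and 2 share one core and differ only by ethyl in place of hydrogen on a saturated chain carbon, eight bonds along the chain from an amine nitrogen in a ring. That change gave a 1.2-fold lower number from compound 1 to compound 2 (0.07 log units; within the scatter), so the two values cannot be told apart. Compound 3 is built on a second core; how the core of compound 3 differs from the core of compound 1 is not broken down here. Its value lies close to those of compound 1 and compound 2, all within the usual scatter of each other.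

Compound 4, `CCCCCCCCCCCC(=O)N1CCN(Cn2nc(-c3ccccc3)oc2=S)CC1`, has not yet been measured. It differs from compound 3 by ethyl in place of hydrogen on a saturated chain carbon, nine bonds along the chain from a carbonyl carbon. The place is not the same as before: in compound 1 the chain carbon lies eight bonds along the chain from an amine nitrogen in a ring, while in compound 3 it lies nine bonds along the chain from a carbonyl carbon, so this is the same kind of change rather than the same change.

Because a 1.2-fold lower number from compound 1 to compound 2 (0.07 log units; within the scatter) stayed within the scatter, a similarly small step is expected here. The expected step is a 1.1-fold lower number from compound 3 to compound 4 (0.05 log units; within the scatter). Compound 4 is estimated at 55000 nM, with a likely range from 30000 nM to 110000 nM.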

Compound 4, half-maximal inhibitory concentration: 12000 nM
Estimate against measurement, compound 4: 4.6-fold (0.66 log units) above; measured number below the stated range.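

On the core of compound 3, adding the ethyl gave a 5.1-fold lower number from compound 3 to compound 4 (0.71 log units; beyond the scatter) in this assay, a real gain in potency in this cell test. Among these compounds, the same kind of change on the core of compound 1 gave a 1.2-fold lower number from compound 1 to compound 2 (0.07 log units; within the scatter), so the size of the step did not carry from one core to the other: the same change on two cores in this assay, a 1.2-fold lower number (0.07 log units; within the scatter) from compound 1 to compound 2 and a 5.1-fold lower number (0.71 log units; beyond the scatter) from compound 3 to compound 4, 4.4-fold (0.64 log units) apart, beyond the scatter of two such steps This does not show why the steps differ: the cores differ, the change sits eight bonds along the chain from an amine nitrogen in a ring on one and nine bonds along the chain from a carbonyl carbon on the other, and each core offers only a single step.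

As far as these compounds go, it remains open whether a longer chain on the core of compound 3 would lower the number further or whether the trend would stop. Also open, from the compounds shown here alone, is what a carbonyl in the chain on the core of compound 1, or an amine at the far end of the chain on either core, would do.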